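This account rests on a few compounds, and the source may have more. Where it says the series, first, only, none or still open, it means among the compounds named here.

Going by the values given here, compound 2 `Cn1cc(/C=C2/C(=O)Nc3ccccc32)c2cc(Nc3nccc(-c4ccc(O)cc4)n3)ccc21` is the only compound here with a numbered result: in a functional assay on PA-1 cells (Homo sapiens) for cytotoxicity, read by MTT assay, with a stated time of 48 h (on this read-out higher numbers stand for weaker inhibition and lower numbers for stronger inhibition), compound 2 gives 9270 nM. Compound 1 `Cc1ccc(-c2ccnc(Nc3ccc4c(c3)c(/C=C3/C(=O)Nc5ccccc53)cn4C)n2)cc1` reaches only a limit of the assay, > 100000 nM, in this assay. Between them stands an at least 10-fold lower number from compound 1 to compound 2 (1.03 log units; beyond the scatter). Compound 3 `Cn1cc(/C=C2/C(=O)Nc3ccccc32)c2cc(Nc3nccc(-c4ccc(Cl)cc4)n3)ccc21` alters compound 2 by chloro in place of hydroxy on an aromatic carbon. Going by these compounds, since the step of an at least 10-fold lower number from compound 1 to compound 2 (1.03 log units; beyond the scatter) moved the other way on swapping methyl for hydroxy, the expectation is for a rise in the number, a 4.3-fold higher number from compound 2 to compound 3 (0.63 log units; beyond the scatter), though how far a chloro tracks a methyl is untested. Compound 3 is therefore expected at 40000 nM, between 10000 nM and 150000 nM.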

Compound 3, half-maximal inhibitory concentration: 2430 nM
For compound 3 the middle estimate is 16-fold (1.22 log units) above the measured one; the measured number lies below the stated range.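

Chloro in place of hydroxy gives a 3.8-fold lower number from compound 2 to compound 3 (0.58 log units; beyond the scatter) in this assay, so a hydrogen-bond donor at this ring carbon is not needed for the lower number. Chloro in place of methyl gives an at least 41-fold lower number from compound 1 to compound 3 (1.61 log units; beyond the scatter), so at this place the two groups are far from interchangeable. Compound 1 gives a limit rather than a number, so the true size of that step is unknown: the limit of > 100000 nM in this assay, at which 1 of the 3 values shown sits.

Going by these compounds, how fluoro, methoxy or an amine would read at this place remains open. So does whether chloro would give the same result on another carbon of this ring.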